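From Propyl to Isopropyl on a Shared Core

The source may hold more compounds than are shown below. What is called first, only, known or untested is meant among the compounds shown, and "the series" means these compounds.

In a functional assay on A-431 cells (Homo sapiens) for inhibition, with a stated time of 72 h (a higher number here means a weaker inhibitor, a lower number a stronger inhibitor), compound 1 (`Oc1c(CN2CCCCC2)ccc2cccnc12`) gives 9770 nM and compound 2 (`CCCOCc1cc(CN2CCCCC2)c(O)c2ncccc12`) gives 6760 nM. These two values lie within the scatter of each other, so compound 2 cannot be placed apart from compound 1 on these numbers.

Compound 3 (`CC(C)OCc1cc(CN2CCCCC2)c(O)c2ncccc12`) has the same atoms as compound 2, joined differently: isopropyl in place of propyl on an oxygen on a saturated carbon. This places isopropyl in place of propyl on an oxygen on a saturated carbon, which also reads as propoxymethyl to isopropoxymethyl.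

Going by the values given here, no measured step makes this exchange directly. Among the compounds with values here, the only step that bears on it is the one introducing the whole propoxymethyl group, a 1.4-fold lower number from compound 1 to compound 2 (0.16 log units; within the scatter), and that step did not go beyond the scatter. A rearrangement within that chain is therefore expected to leave this assay without a change beyond the scatter, in neither direction.

The expected step is a 1.0-fold higher number from compound 2 to compound 3 (0.02 log units; within the scatter). For compound 3 the estimated value is 7000 nM, with an expected range of 3500 nM to 14000 nM.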

Compound 3, half-maximal inhibitory concentration: 7410 nM
Compound 3: the middle estimate sits 1.1-fold (0.02 log units) below what was measured; the range from low to high includes it.
By their numbers in this assay, from the lowest: compounds 2, 3 and 1 (each within the scatter of the next).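

In this assay, isopropyl in place of propyl on an oxygen on a saturated carbon gives a 1.1-fold higher number from compound 2 to compound 3 (0.04 log units; within the scatter), so the two chains cannot be told apart at this place on these numbers. The isopropoxymethyl group, set in place of hydrogen on an aromatic carbon, gives a 1.3-fold lower number from compound 1 to compound 3 (0.12 log units; within the scatter), which means that a second chain at this position, and not only propoxymethyl, stays within the scatter of compound 1. Nothing measured here speaks to why the three compounds lie so close together.

The compounds shown leave open whether any group at this position can move the number in this assay beyond the scatter, as neither of the two chains does so. A longer chain such as hexyloxymethyl, or a group of another kind such as an aminomethyl or a carboxylic acid in place of the ether chain, would put that question to the test on the shared core.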